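Amide Amine Swap at the Carbonyl and HepG2 Cytotoxicity

The source may hold more compounds than are shown below. What is called first, only, known or untested is meant among the compounds shown, and "the series" means these compounds.

Compound 2 `CC1CCN(C(=O)CCCNC(=O)c2ccc(S(C)(=O)=O)c([N+](=O)[O-])c2)CC1` carries a 4-methylpiperidin-1-yl group on a carbonyl carbon of the shared core. In an ADME assay on HepG2 cells (Homo sapiens) for cytotoxicity, read by CellTiter-Glo and ATP content, with a stated time of 72 h (on this read-out higher numbers stand for an effect only at larger amounts of compound and lower numbers for an effect already at smaller amounts), compound 2 reaches only a limit of the assay, > 27000 nM. Compound 1 `CN(Cc1cccc(F)c1)C(=O)CCCNC(=O)c1ccc(S(C)(=O)=O)c([N+](=O)[O-])c1` differs from it solely at that carbonyl carbon. In this assay compound 1 likewise gives only a limit, > 27000 nM. The step that the two limits leave unreadable from compound 1 to compound 2 therefore cannot be read, and both values sit at the limit of > 27000 nM in this assay, at which 2 of the 2 values shown sit. Compound 3 `CS(=O)(=O)c1ccc(C(=O)NCCCC(=O)N2Cc3ccccc3C2)cc1[N+](=O)[O-]` brings the next change at the same place: a group of 9 heavy atoms (8 carbon, 1 nitrogen; one five-membered non-aromatic ring with 1 hetero atom, one six-membered aromatic ring of carbon only) in place of a group of 7 heavy atoms (6 carbon, 1 nitrogen; one six-membered non-aromatic ring with 1 hetero atom), on a carbonyl carbon. For the measured compounds named here, no measured step at this position yields a readable size, so there is no step to carry over, and the expectation rests on the two limits alone. Compound 3 is therefore expected to return another limit rather than a number, with an estimated step that the limit leaves unreadable from compound 2 to compound 3 that stays within the scatter. The estimate for compound 3 is 30000 nM, between 12000 nM and 70000 nM.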

Compound 3, half-maximal effective concentration: > 27000 nM
Compound 3: a limit, no number; the forecaster's own chance of this, stated with the estimate: 80%; the middle value does not contradict the limit.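

In this assay compound 3 gives > 27000 nM, which is again a limit and not a number. No step among compound 1, compound 2 and compound 3 can therefore be read: the limit of > 27000 nM in this assay, at which 3 of the 3 values shown sit.

The compounds shown leave open whether the group on the carbonyl carbon shifts this read-out at all.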